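A Single Atom Swap in the Ester of Compound 1

The compounds below may be only part of what the source reports. "The series", "measured", "known", "first", "only" and "open" are said of these compounds alone.

Within the data shown here, in a functional assay on MDA-MB-231 cells (Homo sapiens) for cytotoxicity, read by MTT assay, with a stated time of 72 h (a higher number here means that more compound is needed for the effect, a lower number that less compound is needed), compound 1 (`CCc1cccc2c(OC)c(-c3occ(C)c3C(=O)OC)ccc12`) gives 1.3 ug/mL, the only actual number among the three measured compounds. Compound 2 (`CCOc1c(-c2occ(C)c2C(=O)O)ccc2c(CC)cccc12`) gives > 10 ug/mL, which is a limit of the assay and not a number. Compound 3 (`CCCOC(=O)c1c(C)coc1-c1ccc2c(CC)cccc2c1OC`) gives > 10 ug/mL, which is also a limit.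

Compound 4 (`CCc1cccc2c(OC)c(-c3occ(C)c3C(=S)OC)ccc12`) keeps the core of compound 1 and alters one group: a group of 4 heavy atoms (2 carbon, 1 oxygen, 1 sulfur; no ring) in place of a group of 4 heavy atoms (2 carbon, 2 oxygen; no ring), on an aromatic carbon. The methoxycarbonyl that leaves sits on an aromatic carbon of a five-membered aromatic ring with 1 oxygen, and the new group takes the same place.

Among the measured compounds shown here, only one measured step touches this ester: an at least 7.6-fold higher number from compound 1 to compound 3 (0.88 log units; beyond the scatter). It shows that this assay can respond to a change in this group, but it alters the chain on the ester oxygen and leaves the carbonyl untouched, so it bears on compound 4 only indirectly. Compound 2 differs from compound 1 in more than one place and gives no clean comparison. For the measured compounds named here, no measured step replaces the carbonyl oxygen.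

A small estimated step is therefore expected, leaning toward a higher number: a 1.9-fold higher number from compound 1 to compound 4 (0.28 log units; within the scatter). The expected value for compound 4 is 2.5 ug/mL, with an estimated range from 0.7 ug/mL to 9 ug/mL.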

Compound 4, concentration for half-maximal effect: 5.8 ug/mL
The estimate for compound 4 lay 2.3-fold (0.37 log units) below the measured number; measured number inside the range.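

Replacing the carbonyl oxygen of the ester with sulfur, the only change shown at the carbonyl itself, does not leave the read-out untouched in this assay: a 4.5-fold higher number from compound 1 to compound 4 (0.65 log units; beyond the scatter). Until now, only the chain on the ester oxygen had been seen to matter, whereas this step shows that the position also responds to a single-atom change within the carbonyl, with the size of the ester group held at 4 heavy atoms. The comparison with the longer ester gives an at least 1.7-fold lower number from compound 3 to compound 4 (0.23 log units; that floor lies within the scatter), so it does not rank those two compounds, and the true size of the gap stays hidden at the ceiling of the assay: the limit of > 10 ug/mL in this assay, at which 2 of the 4 values shown sit.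

Going by these compounds, it remains open whether the loss follows from the carbonyl oxygen specifically or would appear with any replacement of the ester, such as an amide or a nitrile on the same aromatic carbon. On these data alone, it is also open whether sulfur in place of the ester's other oxygen, or an ethyl ester, would move the number by a similar amount.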